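Aryl in place of propyl on the fused core

The source may hold more compounds than are shown below. What is called first, only, known or untested is meant among the compounds shown, and "the series" means these compounds.

Going by the values given here, the two measured members share one core: compound 1 `CCc1nn2c(C(C)c3ccc(CC(C)C)cc3)nnc2s1` and compound 2 `CCCc1nn2c(C(C)c3ccc(CC(C)C)cc3)nnc2s1`. In a functional assay on the whole organism (strain Wistar albino) for inhibition, with Rattus norvegicus as the target, read by paw edema, with stated times of 30 min and 1 h, at a dose of 20 mg/kg by the oral route (on this read-out lower numbers stand for less inhibition and higher numbers for more inhibition at the one dose given (going by the name of the read-out)), compound 1 gives 22%, and compound 2 gives 15%. Among the compounds with values here, the only measured step is a number 7 percentage points lower from compound 1 to compound 2 (within the scatter), so compound 2 and compound 1 stand within the scatter of each other, with no order between them to claim. Compound 3 `CC(C)Cc1ccc(C(C)c2nnc3sc(-c4ccc(Br)cc4)nn23)cc1` differs from compound 2 by 4-bromophenyl in place of propyl on an aromatic carbon. The measured step concerns methyl in place of hydrogen on a saturated chain carbon, a change of another kind than the exchange of propyl for 4-bromophenyl, so it bears only weakly on the new step; nothing measured in this assay speaks to an aromatic ring entering at this place. The expected step is a number 5 percentage points higher from compound 2 to compound 3 (within the scatter), a movement not expected to exceed the scatter. Compound 3 is estimated at 20%, between 5% and 40%.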

Compound 3, a percentage reported as inhibition, in the whole organism at one dose (the size of the read-out at that dose, not a potency): 58%
The estimate for compound 3 lay 38 percentage points below the measured number; the measured number lies above the stated range.
By their numbers in this assay, from the lowest: compounds 2 and 1 (each within the scatter of the next); then compound 3.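

In this assay, 4-bromophenyl in place of propyl on this aromatic carbon gives a number 43 percentage points higher from compound 2 to compound 3 (beyond the scatter) and 4-bromophenyl in place of ethyl gives a number 36 percentage points higher from compound 1 to compound 3 (beyond the scatter). The ethyl and propyl compounds sit within the scatter of each other, so the earlier pair showed no response at this carbon, whereas the exchange of either chain for 4-bromophenyl shows that the position does respond, and compound 3 stands clearly above both. Nothing at hand explains this gain.

On these data alone, whether the six-membered aromatic ring alone carries the gain, or the bromine shares in it, stays open; plain phenyl and 4-chlorophenyl at this carbon would separate the two. Also open, as far as these compounds go, are how an amine or a longer chain would read here and how compound 3 reads at other doses.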